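This account rests on a few compounds, and the source may have more. Where it says the series, first, only, none or still open, it means among the compounds named here.

Measured compounds:
- compound 1, `O=C(/C=C/c1ccc(F)cc1)O/C(=N/C1CCCCC1)NC1CCCCC1`: 85.5%
- compound 2, `Cc1ccc(/C=C/C(=O)O/C(=N/C2CCCCC2)NC2CCCCC2)cc1`: 95.5%
- compound 3, `COC(=O)[C@@H]1COC(/C=C/c2ccc(F)cc2)=N1`: 18.6%

In an ADME assay on Vero cells (Chlorocebus sabaeus) for cytotoxicity, read by WST assay, tested at 100 ug/mL (on this read-out lower numbers stand for a stronger effect and higher numbers for a weaker effect at the one concentration tested), compound 3 stands lowest of the three numbers, which on this read-out means the strongest effect; compound 1 sits beyond the scatter above it and compound 2 further still. The unmeasured compound 4, `COC(=O)[C@@H]1COC(/C=C/c2ccc(C)cc2)=N1`, differs from compound 3 by one change: methyl in place of fluoro on an aromatic carbon. The same change has been measured once before, on a different core, in the pair of compound 1 and compound 2, where a number 10 percentage points higher from compound 1 to compound 2 (within the scatter). That single step stayed within the scatter, so it gives no sign of a real shift in either direction, though it was a small rise rather than a fall. For compound 4 a step of similar size is therefore expected, a number 6.4 percentage points higher from compound 3 to compound 4 (within the scatter), not clearly beyond the scatter. The estimated value for compound 4 in this assay is 25%, with a likely range from 10% to 45%.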

Compound 4, a percentage reported as activity, at one concentration (the size of the read-out at that concentration, not a potency): 17%
The estimate for compound 4 lay 8 percentage points above the measured number, within the range that was stated.
By their numbers in this assay, from the lowest: compounds 4 and 3 (each within the scatter of the next); then compounds 1 and 2 (each within the scatter of the next).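

In this assay, methyl in place of fluoro, para to a large group, has now been read on a second core, and there it again gives no real shift (a number 1.6 percentage points lower from compound 3 to compound 4 (within the scatter)). Until now the swap had been read on one core only, so it could not be told whether so small a step belonged to that core alone. The two readings now agree within the scatter, so at this position the choice between these two groups made no clear difference on either core: the same change on two cores in this assay, a number 10 percentage points higher (within the scatter) from compound 1 to compound 2 and a number 1.6 percentage points lower (within the scatter) from compound 3 to compound 4, 11.6 percentage points apart, within the scatter of two such steps.

Going by these compounds, how this position responds to an amine, a carboxylic acid or a longer chain remains open. Also open, on these data alone, is whether the same small step would appear on a further core or at other concentrations, since each compound was read at a single concentration.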